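A few compounds are considered here, and "the series" means these few. Any claim that something is new, unique, unknown or untested is made for them only; others in the source may bear on it.

Of the compounds shown here, two carry a number so far. In a functional assay on CHO cells for antagonist activity at Orexin/Hypocretin receptor type 1 (Homo sapiens), read by FLIPR and calcium flux (a higher number here means a more potent compound, by a factor of ten per unit of this negative logarithm, a lower number a less potent compound), compound 1, `Cc1cnn(-c2ccc(C)nc2C(=O)N2CC3(CC3)C[C@H]2CNc2ccc(C(F)(F)F)cn2)c1`, gives 8.9. Compound 2, `Cc1cc(C(F)(F)F)cc(NC[C@@H]2CC3(CC3)CN2C(=O)c2nc(C)sc2-c2ccccc2)n1`, gives 7.8 in this assay, the lower of the two, sitting beyond the scatter under compound 1. Compound 3, `Cc1cccc(NC[C@@H]2CC3(CC3)CN2C(=O)c2nc(C)sc2-c2ccccc2)n1`, is compound 2 with hydrogen in place of trifluoromethyl on an aromatic carbon. Within the data shown here, no measured pair shows this change, so its size is open; the expectation is a step of a number 0.50 log units lower from compound 2 to compound 3 (beyond the scatter) in this assay, a moderate loss. Compound 3 is expected to give 7.3 in this assay, within 6.6 to 7.9.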

Compound 3, negative logarithm of the antagonist equilibrium constant: 7.3
Estimate against measurement, compound 3: no gap at the digits printed, within the range that was stated.
By their numbers in this assay, from the lowest: compound 3; then compound 2; then compound 1.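

In this assay, among these compounds, the exchange of trifluoromethyl for hydrogen on the aromatic carbon opposite the ring nitrogen gives the first single-place step: a number 0.50 log units lower from compound 2 to compound 3 (beyond the scatter). The trifluoromethyl group therefore adds to the number at this position, but the modest size of the step shows that it is not essential. No measurement available here accounts for the step.

Going by these compounds, whether a chlorine atom, a methoxy group or a nitrile at this carbon would recover the loss remains open. So does the size of the same exchange with other amide partners.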